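Adding a Methoxy Group to Compound 1

The compounds below may be only part of what the source reports. "The series", "measured", "known", "first", "only" and "open" are said of these compounds alone.

Compound 1 `COc1ccc(-c2cc(/C=C/C(=O)c3ccc(N)cc3)[nH]n2)cc1`: 2070 nM
Compound 2 `COc1ccc(C(=O)/C=C/c2cc(-c3cc(OC)c(OC)c(OC)c3)n[nH]2)cc1`: 1720 nM
Compound 3 `COc1cc(-c2cc(/C=C/C(=O)c3ccc(F)c(F)c3)[nH]n2)cc(OC)c1OC`: 2960 nM

In a functional assay on NCI-H460 cells (Homo sapiens) for inhibition, read by sulforhodamine B assay, with a stated time of 48 h (a lower number here means a stronger inhibitor of growth, a higher number a weaker inhibitor of growth), compound 1 stands second highest of the three numbers. Compound 2 sits nearest, and compound 3 furthest, yet both lie within the scatter of compound 1. Compound 4 `COc1ccc(-c2cc(/C=C/C(=O)c3ccc(N)cc3)[nH]n2)cc1OC` differs from compound 1 by methoxy in place of hydrogen on an aromatic carbon. Among the measured compounds shown here, the only measured step, a 1.7-fold higher number from compound 2 to compound 3 (0.24 log units; within the scatter), concerns the carbonyl side and does not bear on this ring. Compound 1 and compound 2 differ in more than one place, including that ring, and their values lie within the scatter. With nothing pointing either way, the step of a 1.1-fold lower number from compound 1 to compound 4 (0.04 log units; within the scatter) is expected to stay within the scatter. Compound 4 is therefore estimated at 1900 nM, between 800 nM and 4500 nM.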

Compound 4, concentration for 50% growth inhibition: 2030 nM
Beside the measured number, compound 4's estimate is 1.1-fold (0.03 log units) below it; low and high end bracket the measured number.
By their numbers in this assay, from the lowest: compounds 2, 4, 1 and 3 (each within the scatter of the next).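

In this assay, among the compounds shown here, the step of a 1.0-fold lower number from compound 1 to compound 4 (0.01 log units; within the scatter) gives the first direct reading at this position, where the earlier compounds differed from compound 1 in more than one place. Methoxy in place of hydrogen on this aromatic carbon, ortho to a methoxy group, thus leaves growth inhibition unchanged within the scatter. No measured evidence accounts for this result.

On these data alone, whether a hydroxyl, a fluorine, an amine or a longer chain at this place would behave the same remains open. As far as these compounds go, it is also open whether the added methoxy would have the same effect with a different group on the carbonyl side.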